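Coumarin-Type Series: From Acetyl to Carbamoyl

The compounds below may be only part of what the source reports. "The series", "measured", "known", "first", "only" and "open" are said of these compounds alone.

Measured compounds:
compound 1, `CC(C)Oc1cc(=O)oc2cc(OCc3cccc(Cl)c3)ccc12`: 3%
compound 2, `O=c1cc(Oc2ccccc2)c2ccc(OCc3cccc(Cl)c3)cc2o1`: 0%
compound 3, `CC(=O)c1cc(=O)oc2cc(OCc3cccc(Cl)c3)ccc12`: 0%

Of the compounds shown here, three sharing one core have been tested in an assay on isolated protein (strain Sprague-Dawley) for inhibition of Amine oxidase [flavin-containing] A (Rattus norvegicus), read by spectrophotometry, with a stated time of 5 min, tested at 10 uM; a higher number here means more inhibition at the concentration tested (going by the name of the read-out), a lower number less inhibition. Compound 1, `CC(C)Oc1cc(=O)oc2cc(OCc3cccc(Cl)c3)ccc12`, gives 3% in this assay. Compound 2, `O=c1cc(Oc2ccccc2)c2ccc(OCc3cccc(Cl)c3)cc2o1`, gives 0%, and compound 3, `CC(=O)c1cc(=O)oc2cc(OCc3cccc(Cl)c3)ccc12`, gives 0%. Compound 3 stands level with compound 2 at the digits shown, the two together being the lowest of the three numbers; its nearest neighbour is compound 2, with no change at the digits printed from compound 2 to compound 3 (within the scatter), and its furthest is compound 1, with a number 3 percentage points lower from compound 1 to compound 3 (within the scatter). All three values lie within the scatter of one another, so none can be called stronger or weaker.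

The next compound, compound 4, `NC(=O)c1cc(=O)oc2cc(OCc3cccc(Cl)c3)ccc12`, differs from compound 3 in one place: amino in place of methyl on a carbonyl carbon, which read one bond further out is acetyl to carbamoyl. For the measured compounds named here, no measured step touches the carbonyl carbon itself; the steps that bear on it are those arriving at compound 3, a number 3 percentage points lower from compound 1 to compound 3 (within the scatter) and no change at the digits printed from compound 2 to compound 3 (within the scatter), both within the scatter. Since every change so far has left this assay essentially unmoved, no step beyond the scatter is expected here either: the estimated step is a number 2 percentage points higher from compound 3 to compound 4 (within the scatter). For compound 4 the expected value is therefore 2%, with a range of 0% to 12%.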

Compound 4, a percentage reported as inhibition, at one concentration (the size of the read-out at that concentration, not a potency): 14%
The estimate for compound 4 lay 12 percentage points below the measured number, outside the stated range (above it).
By their numbers in this assay, from the lowest: compounds 2, 3 and 1 (each within the scatter of the next); then compound 4.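

In this assay, for the compounds shown here, the swap of methyl for amino on the carbonyl carbon gives the first step that rises beyond the scatter, a number 14 percentage points higher from compound 3 to compound 4 (beyond the scatter), which shows that a change at this position can move the read-out. The carbamoyl group also stands apart from the two groups joined through oxygen at the same aromatic carbon, with a number 14 percentage points higher from compound 2 to compound 4 (beyond the scatter) against phenoxy and a number 11 percentage points higher from compound 1 to compound 4 (beyond the scatter) against isopropoxy, yet a carbonyl on that aromatic carbon is not enough by itself, as acetyl in compound 3 carries one without such a rise. No supporting measurement here bears on why the amino group makes this difference.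

Going by these compounds, the read-out is a percentage at one concentration, so compound 4 has no potency attached to it, and it is open whether the inhibition would grow at higher concentrations. On these data alone, it is also open whether the rise is specific to the unsubstituted amino group or would persist with a methylamino group on the same carbonyl carbon, or with a hydroxyl there, which would make a carboxylic acid.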